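Terminal hydroxy on the butyl chain of compound 2

A few compounds are considered here, and "the series" means these few. Any claim that something is new, unique, unknown or untested is made for them only; others in the source may bear on it.

Among the measured compounds shown here, compound 2 `CCCCn1cc(C(=O)Nc2ccc(C)c(S(=O)(=O)N3CCOCC3)c2)c(-c2ccc(C)cc2)n1` gives 11500 nM in an assay on HEK-293T cells for inhibition of Bile acid receptor (Homo sapiens), read by a beta-lactamase reporter, with a stated time of 16 h (a lower number here means a stronger inhibitor, a higher number a weaker inhibitor), the higher of the two numbers known; compound 1 `Cc1ccc(-c2nn(-c3ccc(Cl)cc3Cl)cc2C(=O)Nc2ccc(C)c(S(=O)(=O)N3CCOCC3)c2)cc1` gives 1240 nM, and the step of a 9.3-fold higher number from compound 1 to compound 2 (0.97 log units; beyond the scatter) is the only one in hand. Compound 3 `Cc1ccc(-c2nn(CCCCO)cc2C(=O)Nc2ccc(C)c(S(=O)(=O)N3CCOCC3)c2)cc1` differs from compound 2 by hydroxy in place of hydrogen on a saturated chain carbon, four bonds along the chain from an aromatic nitrogen. For the measured compounds named here, no measured step touches a change of this kind: the one known step swaps the whole substituent on the aromatic nitrogen and says nothing about a hydroxy at the chain end. The expectation is therefore a step of a 1.2-fold lower number from compound 2 to compound 3 (0.06 log units; within the scatter), not beyond the scatter. Compound 3 is estimated at 10000 nM, range 4000 nM to 30000 nM.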

Compound 3, half-maximal inhibitory concentration: 2610 nM
For compound 3 the middle estimate is 3.8-fold (0.58 log units) above the measured one, and the stated range ends above it.
By their numbers in this assay, from the lowest: compound 1; then compound 3; then compound 2.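

Hydroxy in place of hydrogen on a saturated chain carbon, four bonds along the chain from an aromatic nitrogen, is not a silent change in this assay (a 4.4-fold lower number from compound 2 to compound 3 (0.64 log units; beyond the scatter)). The 4-hydroxybutyl group still falls short of 2,4-dichlorophenyl on that nitrogen (a 2.1-fold higher number from compound 1 to compound 3 (0.32 log units; beyond the scatter)), so the chain end matters but compound 1 keeps the lower number. No evidence is available to explain this step.

Open, on these data alone, is how a longer or shorter hydroxyalkyl chain would read here. Also open, as far as these compounds go, is whether a methyl ether, an amine or a carboxylic acid at the chain end would match hydroxy.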